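Bromo in place of cyclopropyl on the shared core

A few compounds are considered here, and "the series" means these few. Any claim that something is new, unique, unknown or untested is made for them only; others in the source may bear on it.

Three analogues share one core. Compound 1 `C[C@@H]1CN(c2scnc2-c2nc3ccccc3[nH]2)CCN1C(=O)Cn1cnc2cccnc21` gives 830 nM in a functional assay on U2OS cells for antagonist activity at C-X-C chemokine receptor type 3 (Homo sapiens), read by beta-arrestin recruitment; on this read-out lower numbers stand for stronger inhibition and higher numbers for weaker inhibition; compound 2 `Cc1nc(-c2nc3ccccc3[nH]2)c(N2CCN(C(=O)Cn3cnc4cccnc43)[C@H](C)C2)s1` gives 1050 nM; compound 3 `C[C@@H]1CN(c2sc(C3CC3)nc2-c2nc3ccccc3[nH]2)CCN1C(=O)Cn1cnc2cccnc21` gives 745 nM, the lowest of the three numbers, though with a 1.1-fold lower number from compound 1 to compound 3 (0.05 log units; within the scatter) and a 1.4-fold lower number from compound 2 to compound 3 (0.15 log units; within the scatter) neither gap exceeds the scatter. Compound 4 `C[C@@H]1CN(c2sc(Br)nc2-c2nc3ccccc3[nH]2)CCN1C(=O)Cn1cnc2cccnc21` carries bromo in place of cyclopropyl on an aromatic carbon. Within the data shown here, the steps that bear on this position, a 1.3-fold higher number from compound 1 to compound 2 (0.10 log units; within the scatter) and a 1.1-fold lower number from compound 1 to compound 3 (0.05 log units; within the scatter), show that hydrogen, methyl and cyclopropyl at this carbon all give numbers within the scatter of one another, so no direction is indicated and no step beyond the scatter is expected in this assay. Compound 4 is therefore expected near 750 nM, between 350 nM and 1600 nM. The expected step is a 1.0-fold higher number from compound 3 to compound 4 (0.00 log units; within the scatter).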

Compound 4, half-maximal inhibitory concentration: 126 nM
Compound 4: the middle estimate sits 6.0-fold (0.77 log units) above what was measured; measured number outside the range, below it.
By their numbers in this assay, from the lowest: compound 4; then compounds 3, 1 and 2 (each within the scatter of the next).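

In this assay bromo on this aromatic carbon gives a 5.9-fold lower number from compound 3 to compound 4 (0.77 log units; beyond the scatter) and also an 8.3-fold lower number from compound 2 to compound 4 (0.92 log units; beyond the scatter) and a 6.6-fold lower number from compound 1 to compound 4 (0.82 log units; beyond the scatter) with each step beyond the scatter. The position therefore does respond to substitution, although hydrogen, methyl and cyclopropyl there stay within the scatter of one another. Nothing available here explains the change to bromo.

On these data alone, whether the shift is specific to bromo remains open, as chloro, iodo, a nitrile or an amine at this carbon could test it. As far as these compounds go, whether it carries over to changes elsewhere on the shared core also remains open.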